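Aryl swap on the shared core: trimethoxyphenyl to hydroxyphenyl

The compounds below may be only part of what the source reports. "The series", "measured", "known", "first", "only" and "open" are said of these compounds alone.

Compound 1 `CCN(CC)CCCn1c(=O)c(=Cc2cc(OC)c(OC)c(OC)c2)s/c1=C1\C(=O)Nc2ccc(C)cc21` carries no result in an ADME assay on WI-38 cells (Homo sapiens) for inhibition, read by MTT assay, with a stated time of 72 h (on this read-out lower numbers stand for stronger inhibition and higher numbers for weaker inhibition), where its entry reads "not determined" (no result reported), so it stands without a number there. Among the compounds with values here, the only value in this assay so far comes from compound 2 `CCN(CC)CCCn1c(=O)c(=Cc2ccc(F)c(F)c2)s/c1=C1\C(=O)Nc2cc(F)ccc21`, which gives 4450 nM. Compound 3 `CCN(CC)CCCn1c(=O)c(=Cc2ccc(O)cc2)s/c1=C1\C(=O)Nc2ccc(C)cc21` differs from compound 1 by 4-hydroxyphenyl in place of 3,4,5-trimethoxyphenyl on a double-bonded chain carbon bound to an aromatic carbon. Within the data shown here, with compound 1 unmeasured, no step can be sized; the change is expected to shift this assay by a modest amount at most, in no settled direction, likely within the scatter. Compound 3 is expected to give 5000 nM, in the range 1500 nM to 16000 nM.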

Compound 3, half-maximal inhibitory concentration: 5750 nM
Beside the measured number, compound 3's estimate is 1.2-fold (0.06 log units) below it; the range from low to high includes it.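

In this assay, within the data shown here, compound 1 has no single number, so no step to compound 3 can be read. Going by these compounds, whether 4-hydroxyphenyl in place of 3,4,5-trimethoxyphenyl shifts this read-out stays open, and no supporting data bear on it.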